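Replacing a Chlorophenoxy Chain End with Phenylsulfanyl

The source may report more compounds than this note shows. Statements on the series, on what has been measured and on what is new or still open speak of the compounds shown alone.

Compound 1 `COc1cc(C(C)=O)ccc1OCCCN1CCC(C(c2ccc(Cl)cc2)c2ccc(Cl)cc2)CC1`: 2.51 nM
Compound 2 `Fc1ccc(C(c2ccc(F)cc2)C2CCN(CCCOc3ccc(Cl)cc3)CC2)cc1`: 2 nM

In a functional assay (aorta) with Oryctolagus cuniculus as the target (on this read-out higher numbers stand for weaker binding and lower numbers for tighter binding), compound 1 gives 2.51 nM and compound 2 gives 2 nM. Compound 2 has the lowest of these two numbers, but compound 1 sits within the scatter of it, so no order between them can be claimed. Compound 3 `Fc1ccc(C(c2ccc(F)cc2)C2CCN(CCCSc3ccccc3)CC2)cc1` differs from compound 2 in one place: phenylsulfanyl in place of 4-chlorophenoxy on a saturated chain carbon, three bonds along the chain from an amine nitrogen in a ring. Among the measured compounds shown here, no measured pair shows this change, so the size of its effect is unknown. The step from compound 2 to compound 3 is expected to be small, leaning towards a higher number, a 2.0-fold higher number from compound 2 to compound 3 (0.30 log units; within the scatter). Compound 3 is estimated at 4 nM, between 1.5 nM and 12 nM.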

Compound 3, dissociation constant: 3.16 nM
For compound 3 the middle estimate is 1.3-fold (0.10 log units) above the measured one; the range from low to high includes it.
By their numbers in this assay, from the lowest: compounds 2, 1 and 3 (each within the scatter of the next).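

In this assay there is a 1.6-fold higher number from compound 2 to compound 3 (0.20 log units; within the scatter) on going to phenylsulfanyl in place of 4-chlorophenoxy, so the two compounds cannot be told apart. The chain end therefore accepts sulfur for oxygen and the loss of chlorine together, without a readable shift. Nothing measured here offers an explanation for this result. The compounds shown leave open what the sulfur and the chlorine each contribute, which phenoxy or 4-chlorophenylsulfanyl at this chain end would separate. Also open, from the compounds shown here alone, is how a carboxylic acid or an amine on that ring would read.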